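A few compounds are considered here, and "the series" means these few. Any claim that something is new, unique, unknown or untested is made for them only; others in the source may bear on it.

Measured so far in an assay on CHO cells for displacement of a labelled ligand from transient receptor potential cation channel subfamily V member 1 (Rattus norvegicus); on this read-out lower numbers stand for stronger inhibition and higher numbers for weaker inhibition:
- compound 1 `COc1cc(CNC(=S)NCC(COC(=O)C(C)(C)C)Cc2ccc(C)c(C)c2)cc(Cl)c1O`: 30.9 nM
- compound 2 `COc1cc(CNC(=S)NCC(COC(=O)C(C)(C)C)Cc2ccc(C)c(C)c2)cc(Br)c1O`: 33.1 nM
- compound 3 `COc1cc(CNC(=S)NC(CCc2ccc(C(C)(C)C)cc2)COC(=O)C(C)(C)C)cc(Cl)c1O`: 122 nM

Compound 1 and compound 2 differ only by bromo in place of chloro on an aromatic carbon; this gives a 1.1-fold higher number from compound 1 to compound 2 (0.03 log units; within the scatter). Compound 3 carries a different core, and the difference between the core of compound 3 and the core of compound 1 is not broken down here. In this assay compound 3 sits beyond the scatter from both compound 1 and compound 2, with a higher number than either.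

Compound 4 `COc1cc(CNC(=S)NC(CCc2ccc(C(C)(C)C)cc2)COC(=O)C(C)(C)C)cc(Br)c1O` is not yet measured. It differs from compound 3 by bromo in place of chloro on an aromatic carbon, the same kind of change as that from compound 1 to compound 2. Since the earlier step stayed within the scatter, a step of similar size, a 1.1-fold higher number from compound 3 to compound 4 (0.03 log units; within the scatter), is expected here. Compound 4 is therefore estimated at 130 nM in this assay, between 65 nM and 260 nM.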

Compound 4, inhibition constant: 143 nM
For compound 4 the middle estimate is 1.1-fold (0.04 log units) below the measured one, within the range that was stated.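

Bromo in place of chloro in the 3-chloro-4-hydroxy-5-methoxybenzyl group stays within the scatter on the second core too in this assay, with a 1.2-fold higher number from compound 3 to compound 4 (0.07 log units; within the scatter). The step carries from the core of compound 1 to the core of compound 3 with no difference that can be told from scatter: the same change on two cores in this assay, a 1.1-fold higher number (0.03 log units; within the scatter) from compound 1 to compound 2 and a 1.2-fold higher number (0.07 log units; within the scatter) from compound 3 to compound 4, 1.1-fold (0.04 log units) apart, within the scatter of two such steps. This rests on two cores, one assay and a single change, so it does not show that the step would stay this small on other cores.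

Open, from the compounds shown here alone, are other groups in the same place, such as fluoro, iodo or nitrile. Also open, going by these compounds, is whether the step holds on compounds carrying an amide in place of the pivalate ester.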